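Swapping cyclohexyl for phenyl on a second core

A few compounds are considered here, and "the series" means these few. Any claim that something is new, unique, unknown or untested is made for them only; others in the source may bear on it.

Compound 1, `CN1C(=S)N(C2CCCCC2)C(=O)/C1=C\c1ccc(N(C)CCCO)cc1`, was tested in an assay on isolated protein for inhibition of NADPH oxidase 4 (Homo sapiens), read by chemiluminescence, in the presence of a further agent that is not named here (on this read-out higher numbers stand for weaker inhibition and lower numbers for stronger inhibition), and gives 1190 nM. Compound 2, `CN1C(=S)N(c2ccccc2)C(=O)/C1=C\c1ccc(N(C)CCCO)cc1`, differs from it by one change, (phenyl in place of cyclohexyl on an amide-type nitrogen in a ring), and in this assay compound 2 gives 3390 nM. That change made a clear step, a 2.8-fold higher number from compound 1 to compound 2 (0.45 log units; beyond the scatter). Compound 3, `CCN(CC)c1ccc(/C=C2\C(=O)N(C3CCCCC3)C(=S)N2C)c(OC)c1`, has a different core, and the difference between the two cores is not broken down here. In this assay compound 3 gives 1340 nM, close to compound 1. Compound 4, `CCN(CC)c1ccc(/C=C2\C(=O)N(c3ccccc3)C(=S)N2C)c(OC)c1`, is not yet measured. It differs from compound 3 by the same change, (phenyl in place of cyclohexyl on an amide-type nitrogen in a ring), at a place described in the same words. Because the earlier step was a 2.8-fold higher number from compound 1 to compound 2 (0.45 log units; beyond the scatter), a step of similar size is expected here. The estimated step is a 2.7-fold higher number from compound 3 to compound 4 (0.43 log units; beyond the scatter). Compound 4 is therefore expected to give 3600 nM, most likely between 1800 nM and 7500 nM.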

Compound 4, half-maximal inhibitory concentration: 1170 nM
Estimate against measurement, compound 4: 3.1-fold (0.49 log units) above; the measured number lies below the stated range.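

Phenyl in place of cyclohexyl did not carry over from one core to the other: the same change on two cores in this assay, a 2.8-fold higher number (0.45 log units; beyond the scatter) from compound 1 to compound 2 and a 1.1-fold lower number (0.06 log units; within the scatter) from compound 3 to compound 4, 3.3-fold (0.51 log units) apart, beyond the scatter of two such steps. On the second core the step is a 1.1-fold lower number from compound 3 to compound 4 (0.06 log units; within the scatter), so the clear rise in number seen on the first core cannot be taken as a general result of this swap. Among the compounds shown here, with only two pairs, this does not show which feature of the cores sets the two steps apart, or how the swap would behave on any further core.

Going by these compounds, it remains open whether other groups on the same nitrogen, such as benzyl or ethyl, would also give different steps on the two cores. Which part of the difference between the cores matters also remains unresolved.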